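Changing the Aryl Group on the Ketone

The compounds below may be only part of what the source reports. "The series", "measured", "known", "first", "only" and "open" are said of these compounds alone.

Among the compounds with values here, compound 3 `CC1(C)C=C(n2ccccc2=O)c2cc(C(=O)c3ccc(O)cc3)ccc2O1` gives 5.87 in a functional assay (trachea) with Rattus norvegicus as the target (on this read-out lower numbers stand for lower potency and higher numbers for higher potency (the scale is a negative logarithm)), the highest of the three numbers measured so far, although compound 2 `CCC(=O)c1ccc2c(c1)C(n1ccccc1=O)=CC(C)(C)O2` gives 5.85, which lies within the scatter of it, and compound 1 `CC1(C)C=C(n2ccccc2=O)c2ccccc2O1` gives 5.05. The gain came from placing an acyl group on the aromatic carbon: a number 0.80 log units higher from compound 1 to compound 2 (beyond the scatter) and a number 0.82 log units higher from compound 1 to compound 3 (beyond the scatter). The exchange on the carbonyl carbon itself, a number 0.02 log units higher from compound 2 to compound 3 (within the scatter), was within the scatter. Compound 4 `CC1(C)C=C(n2ccccc2=O)c2cc(C(=O)c3c(F)cccc3F)ccc2O1` differs from compound 3 by 2,6-difluorophenyl in place of 4-hydroxyphenyl on a carbonyl carbon. Within the data shown here, the only measured step at this place, a number 0.02 log units higher from compound 2 to compound 3 (within the scatter), suggests that the group on the carbonyl carbon counts for little here, so compound 4 is expected to show a number 0.07 log units lower from compound 3 to compound 4 (within the scatter), a step not beyond the scatter. Compound 4 is therefore estimated at 5.8, with a range from 5.3 to 6.3.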

Compound 4, logarithm of the reciprocal of the active concentration, log(1/C): 5.99
Compound 4: middle estimate off by 0.19 log units, on the low side; measured number inside the range.
By their numbers in this assay, from the lowest: compound 1; then compounds 2, 3 and 4 (each within the scatter of the next).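

With 2,6-difluorophenyl, which has 0 hydrogen-bond donors and 0 hydrogen-bond acceptors, in place of 4-hydroxyphenyl, the step is a number 0.12 log units higher from compound 3 to compound 4 (within the scatter) and the step from the ethyl ketone is a number 0.14 log units higher from compound 2 to compound 4 (within the scatter) in this series. The number in this assay therefore held without the donor and acceptor of 4-hydroxyphenyl, and the three groups on this carbonyl carbon are not separated. No evidence is available to explain this result. On these data alone, whether an amine, a carboxylic acid or a longer chain on this carbonyl carbon would also leave the number unchanged remains open.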